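The source may report more compounds than this note shows. Statements on the series, on what has been measured and on what is new or still open speak of the compounds shown alone.

Three compounds share one core and differ only in the aryl group attached to it. Compound 1 `COc1cc(-n2cnc3ccc(-c4cccc(N)c4)cc32)cc(OC)c1OC` carries 3-aminophenyl, compound 2 `COc1cc(-n2cnc3ccc(-c4ccc(Cl)cc4)cc32)cc(OC)c1OC` carries 4-chlorophenyl, and compound 3 `COc1cc(-n2cnc3ccc(-c4cccc([N+](=O)[O-])c4)cc32)cc(OC)c1OC` carries 3-nitrophenyl. In a functional assay on A549 cells (Homo sapiens) for antiproliferative activity, read by MTT assay, with a stated time of 72 h (a higher number here means a weaker inhibitor, a lower number a stronger inhibitor), compound 1 gives 640 nM and compound 3 gives 5410 nM. For compound 2 the assay reports only a limit, > 10000 nM. Among the numbers actually read, compound 3 stands highest; the gap to the nearest number is an 8.5-fold higher number from compound 1 to compound 3 (0.93 log units; beyond the scatter). The step of an at least 1.8-fold lower number from compound 2 to compound 3 (0.26 log units; that floor lies within the scatter) rests on a limit, and its floor stays within the scatter.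

Compound 4 `COc1cc(-n2cnc3ccc(-c4ccc(O)cc4)cc32)cc(OC)c1OC` has not been measured yet; it differs from compound 3 by 4-hydroxyphenyl in place of 3-nitrophenyl on an aromatic carbon. Within the data shown here, two measured steps bear on this change: an 8.5-fold higher number from compound 1 to compound 3 (0.93 log units; beyond the scatter) and an at least 1.8-fold lower number from compound 2 to compound 3 (0.26 log units; that floor lies within the scatter). Neither involves a hydroxyl, so the expectation is loose. Compound 4 is expected to give about 2000 nM, within a range from 500 nM to 8000 nM. That would mean an expected step of a 2.7-fold lower number from compound 3 to compound 4 (0.43 log units; beyond the scatter).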

Compound 4, half-maximal inhibitory concentration: 5090 nM
Compound 4: the middle estimate sits 2.5-fold (0.41 log units) below what was measured; measured number inside the range.
By their numbers in this assay, from the lowest: compound 1; then compounds 4 and 3 (each within the scatter of the next). At a limit, above all of these: compound 2.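

In this assay, 4-hydroxyphenyl in place of 3-nitrophenyl on an aromatic carbon gives a 1.1-fold lower number from compound 3 to compound 4 (0.03 log units; within the scatter), so 4-hydroxyphenyl, with 1 hydrogen-bond donor, cannot be told apart from 3-nitrophenyl, with 0 hydrogen-bond donors. Compound 1 stays apart, with an 8.0-fold higher number from compound 1 to compound 4 (0.90 log units; beyond the scatter), which leaves its 3-aminophenyl group as the only one among these four that gives a clearly stronger inhibitor. Compound 2 stands at a limit, so the step of an at least 1.9-fold lower number from compound 2 to compound 4 (0.29 log units; that floor lies within the scatter) gives only a floor and cannot be read as a size: the limit of > 10000 nM in this assay, at which 1 of the 4 values shown sits.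

The step from compound 3 to compound 4 changes both the group and where it sits on the phenyl ring, so these compounds cannot separate the two changes. On these data alone, it also remains open whether compound 1 owes its lower number to the amino group or to its place, and 4-aminophenyl and 3-hydroxyphenyl would bear on that question.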